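Swapping 3-nitrophenyl for 3,4,5-trimethoxyphenyl on compound 1

The compounds below may be only part of what the source reports. "The series", "measured", "known", "first", "only" and "open" are said of these compounds alone.

Measured so far in an ADME assay on L02 cells (Homo sapiens) for cytotoxicity, read by MTT assay, with a stated time of 24 h (a higher number here means a weaker inhibitor, a lower number a stronger inhibitor), for three compounds
- compound 1 `O=C1/C(=C/c2cccc([N+](=O)[O-])c2)CN(S(=O)(=O)c2ccc(F)cc2)C/C1=C\c1cccc([N+](=O)[O-])c1` gives 15500 nM
- compound 2 `COc1cc(/C=C2\CN(S(=O)(=O)c3ccc(F)cc3)C/C(=C\c3cc(OC)cc(OC)c3)C2=O)cc(OC)c1` gives 19800 nM
- compound 3 `CC(=O)Nc1ccc(S(=O)(=O)N2C/C(=C\c3cccc([N+](=O)[O-])c3)C(=O)/C(=C/c3cccc([N+](=O)[O-])c3)C2)cc1` gives 15800 nM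

Compound 1 does not stand apart from the other two, and all three values lie within the scatter of one another, so no order can be drawn among them. Compound 4 `COc1cc(/C=C2\CN(S(=O)(=O)c3ccc(F)cc3)C/C(=C\c3cccc([N+](=O)[O-])c3)C2=O)cc(OC)c1OC` is still unmeasured. Its difference from compound 1 is this: 3,4,5-trimethoxyphenyl in place of 3-nitrophenyl on a double-bonded chain carbon bound to a double-bonded ring carbon and so 3,4,5-trimethoxyphenyl stands in place of 3-nitrophenyl on a double-bonded chain carbon bound to a double-bonded ring carbon.

Among the compounds with values here, the only measured single change is a 1.0-fold higher number from compound 1 to compound 3 (0.01 log units; within the scatter) and it involves acetamido in place of fluoro on an aromatic carbon, not the place altered in compound 4. It therefore bears on this change only indirectly. Compound 2, which has methoxy groups on both sides, gives 19800 nM and compound 1, which has nitro groups, gives 15500 nM and these two values also lie within the scatter of each other. Nothing here points to a shift, so no step beyond the scatter is expected in this assay in either direction. The estimated step is a 1.1-fold higher number from compound 1 to compound 4 (0.04 log units; within the scatter) and it is expected to stay within the scatter. For compound 4 the estimated value is 17000 nM with 9000 nM to 32000 nM as its expected range.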

Compound 4, half-maximal inhibitory concentration: 18800 nM
Beside the measured number, compound 4's estimate is 1.1-fold (0.04 log units) below it; measured number inside the range.
By their numbers in this assay, from the lowest: compounds 1, 3, 4 and 2 (each within the scatter of the next).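

In this assay, putting 3,4,5-trimethoxyphenyl in place of 3-nitrophenyl gives a 1.2-fold higher number from compound 1 to compound 4 (0.08 log units; within the scatter), so the two compounds cannot be told apart in this read-out. This is the first single change shown at this place, on a double-bonded chain carbon bound to a double-bonded ring carbon, as the only earlier step concerned acetamido in place of fluoro on an aromatic carbon; here, a nitro-bearing group gives way to one carrying three methoxy groups with no step beyond the scatter, while compound 4 retains its other 3-nitrophenyl group. No measurement shown offers an account of this result.

The compounds shown leave open whether this assay would also stay within the scatter with a group of another kind at this place, such as an aminomethylphenyl or a carboxyphenyl group, or with a pyridine ring in place of the benzene ring. They also leave open whether 3,4,5-trimethoxyphenyl would read the same way at this place when acetamido stands in place of fluoro.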